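Replacing cyano with iodo at the cytotoxicity limit

This account rests on a few compounds, and the source may have more. Where it says the series, first, only, none or still open, it means among the compounds named here.

Compound 1 `COc1ccc(Cn2ccc3nc(-c4ccccc4)nc-3c2)cc1` and compound 2 `N#Cc1ccc(Cn2ccc3nc(-c4ccccc4)nc-3c2)cc1` share one core and differ in a single group on an aromatic carbon. In an ADME assay on MDBK cells (Bos taurus) for cytotoxicity (on this read-out higher numbers stand for lower toxicity in this test and lower numbers for higher toxicity in this test), compound 1 gives > 100000 nM, which is a limit of the assay and not a number. Compound 2 gives > 100000 nM, which is also a limit. Compound 2 therefore has no exact value of its own. Going by the values given here, the only measured step is a step that the two limits leave unreadable from compound 1 to compound 2, so there is no size to carry forward.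

Compound 3 `Ic1ccc(Cn2ccc3nc(-c4ccccc4)nc-3c2)cc1` has iodo in place of cyano on an aromatic carbon, para to a large group: iodo in place of cyano on an aromatic carbon. The evidence is thin, since it rests on just two compounds. Still, with the limit of > 100000 nM in this assay, at which 2 of the 2 values shown sit, holding for compound 1 and compound 2, no step beyond the scatter is expected in this assay, and a further limit is the likeliest report. The expected step is a number no higher from compound 2 to compound 3 (the limit leaves the size open). Compound 3 is estimated at 100000 nM, with an expected range from 40000 nM to 200000 nM.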

Compound 3, half-maximal cytotoxic concentration: 22000 nM
Compound 3: middle estimate off by 4.5-fold (0.66 log units), on the high side; measured number below the stated range.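

Until now, both groups at this place left the read-out at the limit of the test, which gave no sign that the group here mattered. With iodo that changes: in this assay, iodo in place of cyano gives an at least 4.5-fold lower number from compound 2 to compound 3 (0.65 log units; beyond the scatter), and iodo in place of methoxy gives an at least 4.5-fold lower number from compound 1 to compound 3 (0.65 log units; beyond the scatter). Both steps lie beyond the scatter and are minimum sizes, so the true gaps could be larger, and they show that a change on this aromatic carbon, para to a large group, can raise toxicity in this test while the shared core stays the same. Compound 3 is the only one of the three with a real number, and the comparison of methoxy with cyano remains unreadable: the limit of > 100000 nM in this assay, at which 2 of the 3 values shown sit.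

The compounds shown do not tell whether this drop belongs to iodo alone or would also appear with bromo or chloro at the same place. They also leave open whether an amine or a carboxylic acid here would stay at the limit or fall below it, and they give no reason for the change seen with iodo.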